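A few compounds are considered here, and "the series" means these few. Any claim that something is new, unique, unknown or untested is made for them only; others in the source may bear on it.

In a functional assay on HEY cells (Homo sapiens) for cytotoxicity, read by MTT assay, with a stated time of 72 h (on this read-out higher numbers stand for weaker inhibition and lower numbers for stronger inhibition), three amides of the shared core have been measured: compound 1 (`COc1cccc(CNC(=O)c2nc(Br)c3cccnc3c2N[C@H]2CC[C@H](N)CC2)c1`) gives 7000 nM and compound 2 (`CN(C)c1ccc(CNC(=O)c2nc(Br)c3cccnc3c2N[C@H]2CC[C@H](N)CC2)cc1`) gives 5300 nM while compound 3 (`N[C@H]1CC[C@H](Nc2c(C(=O)NCc3ccc(Cl)cc3)nc(Br)c3cccnc23)CC1`) gives 1000 nM as the lowest of the three. Compound 4 (`N[C@H]1CC[C@H](Nc2c(C(=O)NC3CCCCC3)nc(Br)c3cccnc23)CC1`) differs from compound 3 in one place, with cyclohexyl in place of 4-chlorobenzyl on an amide-type nitrogen. The nearest evidence comes from changes to the group on that nitrogen, which show a 7.0-fold lower number from compound 1 to compound 3 (0.85 log units; beyond the scatter) and a 5.3-fold lower number from compound 2 to compound 3 (0.72 log units; beyond the scatter) as modest steps beyond the scatter, whereas a 1.3-fold lower number from compound 1 to compound 2 (0.12 log units; within the scatter) stays within it. For the measured compounds named here, no measured compound has a non-aromatic ring at this place, so the data offer no direct precedent. Even so, a modest step of similar size towards a higher number is expected. The expected step is a 3.0-fold higher number from compound 3 to compound 4 (0.48 log units; beyond the scatter) in this assay and carries wide uncertainty. For compound 4 the estimate is 3000 nM within an expected range of 900 nM to 10000 nM in this assay.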

Compound 4, half-maximal inhibitory concentration: 5200 nM
Compound 4: the middle estimate sits 1.7-fold (0.24 log units) below what was measured; low and high end bracket the measured number.
By their numbers in this assay, from the lowest: compound 3; then compounds 4, 2 and 1 (each within the scatter of the next).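

In this assay, the first non-aromatic ring on the amide-type nitrogen does not keep the lower number seen with 4-chlorobenzyl (a 5.2-fold higher number from compound 3 to compound 4 (0.72 log units; beyond the scatter)). Cyclohexyl instead stands level with the other two benzyl-type groups (a 1.0-fold lower number from compound 2 to compound 4 (0.01 log units; within the scatter); a 1.3-fold lower number from compound 1 to compound 4 (0.13 log units; within the scatter)), so among these four amides only compound 3, with its 4-chlorobenzyl, stands apart. Nothing available accounts for this result.

The compounds shown do not separate the part played by the chloro from that of the benzyl frame, since they include neither a plain benzyl nor a 4-fluorobenzyl on this nitrogen. They also leave open how smaller rings such as cyclopentyl, or open chains such as n-hexyl, would compare with cyclohexyl.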